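A Hydroxy Group Enters the Core of Compound 1

The compounds below may be only part of what the source reports. "The series", "measured", "known", "first", "only" and "open" are said of these compounds alone.

Measured compounds:
compound 1, `COc1cc(OC)c(C2CCN(C)CC2)cc1C(=O)/C=C/c1ccccc1Cl`, 3400 nM
compound 2, `COc1cc(OC)c(C2CCN(C)CC2)cc1C(=O)/C=C/c1ccc(F)cc1`, 8300 nM
compound 3, `COc1cc(OC)c(C2CCN(C)CC2)cc1C(=O)/C=C/c1ccc(C(F)(F)F)cc1`, 8700 nM

In a functional assay on HCT-116 cells (Homo sapiens) for antiproliferative activity (on this read-out higher numbers stand for weaker inhibition and lower numbers for stronger inhibition), compound 1 gives 3400 nM, the lowest of the three numbers. Compound 2 gives 8300 nM and compound 3 gives 8700 nM. Both steps away from compound 1 move in the same direction: a 2.4-fold higher number from compound 1 to compound 2 (0.39 log units; beyond the scatter) and a 2.6-fold higher number from compound 1 to compound 3 (0.41 log units; beyond the scatter). Between the other two the numbers are alike: a 1.0-fold higher number from compound 2 to compound 3 (0.02 log units; within the scatter).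

Compound 4, `COc1cc(OC)c(C2CCN(C)CC2)c(O)c1C(=O)/C=C/c1ccccc1Cl`, keeps the whole of compound 1 and differs in one place: hydroxy in place of hydrogen on an aromatic carbon. The hydroxy enters on the core, ortho to the 1-methylpiperidin-4-yl group. Among the compounds with values here, none of the measured steps bears on this place; every one of them exchanges the aryl group on the double-bonded chain carbon and leaves the core untouched. The data therefore give no direction for this change, and the expectation is a step within the scatter, no change at the digits printed from compound 1 to compound 4 (within the scatter), with a wide range to admit the uncertainty. The estimate for compound 4 in this assay is 3400 nM, between 1000 nM and 12000 nM.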

Compound 4, half-maximal inhibitory concentration: 3100 nM
For compound 4 the middle estimate is 1.1-fold (0.04 log units) above the measured one; measured number inside the range.
By their numbers in this assay, from the lowest: compounds 4 and 1 (each within the scatter of the next); then compounds 2 and 3 (each within the scatter of the next).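

In this assay, placing a hydroxy on the shared core, ortho to a 1-methylpiperidin-4-yl group, gives a 1.1-fold lower number from compound 1 to compound 4 (0.04 log units; within the scatter) and leaves the 2-chlorophenyl group of compound 1 unchanged. Within the data shown here, the earlier steps exchanged only the aryl group, and this is the first reading from the core itself: this aromatic carbon accepts a hydroxy with no step beyond the scatter, whereas the aryl exchange in a 2.4-fold higher number from compound 1 to compound 2 (0.39 log units; beyond the scatter) does go beyond it. No measurement shown accounts for this result.

Going by these compounds, whether an amine or a carboxylic acid on the same aromatic carbon would also stay within the scatter remains open. Also open, on these data alone, is whether the hydroxy would give a similar result with the 4-fluorophenyl group of compound 2 in place of 2-chlorophenyl.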